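Cytotoxicity notes on the step to compound 4

The source may report more compounds than this note shows. Statements on the series, on what has been measured and on what is new or still open speak of the compounds shown alone.

In an ADME assay on HEK-293T cells (Homo sapiens) for cytotoxicity, read by CCK-8 assay, with a stated time of 48 h (on this read-out higher numbers stand for weaker inhibition and lower numbers for stronger inhibition), compound 1 (`O=C(NCCNS(=O)(=O)c1sccc1-c1ccccc1Oc1ccc(O)c(O)c1)Nc1cc(Cl)cc(Cl)c1`) gives 10700 nM and compound 2 (`O=S(=O)(NCCNC(=S)Nc1cccc(Cl)c1)c1ccc(-c2ccccc2OCc2ccccc2)s1`) gives 10200 nM with the two values within the usual scatter of each other. Compound 3 (`COc1ccc(NC(=S)NCCNS(=O)(=O)c2sccc2-c2ccc(C)cc2Oc2ccc(O)c(O)c2)cc1`) gives > 20000 nM as a limit and not a number.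

Compound 4 (`Cc1ccc(-c2ccsc2S(=O)(=O)NCCNC(=O)Nc2cc(Cl)cc(Cl)c2)c(Oc2ccc(O)c(O)c2)c1`) is still unmeasured. The structural change from compound 3 to compound 4 is a group of 11 heavy atoms (7 carbon, 1 nitrogen, 1 oxygen, 2 chlorine; one six-membered aromatic ring of carbon only) in place of a group of 11 heavy atoms (8 carbon, 1 nitrogen, 1 oxygen, 1 sulfur; one six-membered aromatic ring of carbon only), on an amine nitrogen and the group that enters is (3,5-dichlorophenyl)carbamoyl, on an amine nitrogen. Among the measured compounds shown here, no step between measured compounds is available to size this change. For the measured compounds named here, compound 1 carries the same (3,5-dichlorophenyl)carbamoyl group and gives 10700 nM as the only guide in this assay for what to expect. Going by these compounds, the expected step is an at least 1.8-fold lower number from compound 3 to compound 4 (0.25 log units; that floor lies within the scatter) toward lower numbers, meaning stronger inhibition, and its true size stays open with a limit at its start. For compound 4 the estimated value is 11000 nM with an expected range from 5500 nM to 20000 nM as the estimate stands.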

Compound 4, half-maximal inhibitory concentration: 6700 nM
Estimate against measurement, compound 4: 1.6-fold (0.22 log units) above; low and high end bracket the measured number.
By their numbers in this assay, from the lowest: compounds 4, 2 and 1 (each within the scatter of the next). At a limit, above all of these: compound 3.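

In this assay, (3,5-dichlorophenyl)carbamoyl on the amine nitrogen, in place of the group carried by compound 3, gives an at least 2.9-fold lower number from compound 3 to compound 4 (0.47 log units; beyond the scatter), so this position can move the read-out beyond the scatter. Going by these compounds, the size of that step stays open, as compound 3 stands at a limit and not at a number: the limit of > 20000 nM in this assay, at which 1 of the 4 values shown sits. The second step, methyl in place of hydrogen on an aromatic carbon, is a 1.6-fold lower number from compound 1 to compound 4 (0.20 log units; within the scatter), so this methyl leaves the number within the scatter in this assay.

The entering and leaving groups differ in more than one atom at once, so the share of the chlorine atoms cannot be separated from that of oxygen in place of sulfur. On these data alone, how an amine or a carboxylic acid in place of that methyl would read in this assay stays open.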